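The compounds below may be only part of what the source reports. "The series", "measured", "known", "first", "only" and "open" are said of these compounds alone.

Measured so far in a functional assay for antagonist activity, with Cavia porcellus as the target; a lower number here means a stronger inhibitor, a higher number a weaker inhibitor:
- compound 1 `CCN(CC)CC#CCCC1(C(C)(O)c2ccccc2)SCCCS1` with 2510 nM
- compound 2 `CN(CC#CCCC1(C(O)(c2ccccc2)c2ccccc2)SCCCS1)CCCc1ccccc1` with 1630 nM
- compound 3 `CN(C)CC#CCCC1(C(O)(c2ccccc2)c2ccccc2)SCCCS1` with 1810 nM

In this assay compound 3 gives 1810 nM and is not separated from the other two compounds. Its number lies within the scatter of those of compound 1 and compound 2, so the three form a single group without any order.

Compound 4 `CCCN(CC#CCCCC1(C(O)(c2ccccc2)c2ccccc2)SCCCS1)CCC` has not yet been measured. Its change from compound 3 is a group of 11 heavy atoms (10 carbon, 1 nitrogen; no ring) in place of a group of 6 heavy atoms (5 carbon, 1 nitrogen; no ring), on a saturated chain carbon, two bonds along the chain from a saturated ring carbon where the group leaving is 3-(dimethylamino)prop-1-yn-1-yl and the place is on a saturated chain carbon, two bonds along the chain from a saturated ring carbon.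

Within the data shown here, one measured step bears on this change, and only in part. It is a 1.1-fold higher number from compound 2 to compound 3 (0.05 log units; within the scatter) with hydrogen in place of phenethyl on a saturated chain carbon bound to an amine nitrogen. Among the measured compounds shown here, no measured step covers a change of this extent, so the range has to stay wide. On that small step, no shift beyond the scatter is expected in this assay for this change.

The expected step is a 1.0-fold higher number from compound 3 to compound 4 (0.02 log units; within the scatter) and it carries much uncertainty. For compound 4 the estimated value is 1900 nM with an expected range from 650 nM to 5500 nM in the measurement to come.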

Compound 4, antagonist equilibrium constant: 560 nM
Compound 4: the middle estimate sits 3.4-fold (0.53 log units) above what was measured; measured number below the stated range.
By their numbers in this assay, from the lowest: compound 4; then compounds 2, 3 and 1 (each within the scatter of the next).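

In this assay, among these compounds, putting the group of 11 heavy atoms in place of 3-(dimethylamino)prop-1-yn-1-yl gives a 3.2-fold lower number from compound 3 to compound 4 (0.51 log units; beyond the scatter) and is the first step in this set to lie beyond the scatter, so this place, on a saturated chain carbon, two bonds along the chain from a saturated ring carbon, does respond to change. The earlier step, a 1.1-fold higher number from compound 2 to compound 3 (0.05 log units; within the scatter) with hydrogen in place of phenethyl on a saturated chain carbon bound to an amine nitrogen, showed no such shift, and that flat result did not carry over to this larger change. No measurement at hand gives a reason for the step.

The change alters the chain that carries the triple bond and the groups on the amine nitrogen together, so the compounds shown cannot tell which of the two accounts for the step. Going by these compounds, a dimethylamino group on the longer chain, or a dipropylamino group on the shorter one, would separate the two, and how a cyclic amine such as piperidine would behave on either chain remains open.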